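Moving the ring nitrogen in a urea-linked bicyclic aryl group

The source may report more compounds than this note shows. Statements on the series, on what has been measured and on what is new or still open speak of the compounds shown alone.

Compound 1 `C[C@@H]1CN([C@@H](C)CO)C(=O)c2cccc(NC(=O)Nc3nccc4ccccc34)c2O[C@H]1CN(C)S(=O)(=O)c1ccc2c(c1)OCCO2` gives 700 nM in a physicochemical assay for solubility, read by HPLC, in phosphate buffer, measured as thermodynamic solubility, with a stated time of 24 h, at pH 7.4; a higher number here means a more soluble compound, a lower number a less soluble compound. Compound 2 `C[C@@H]1CN([C@@H](C)CO)C(=O)c2cccc(NC(=O)Nc3cccc4ncccc34)c2O[C@H]1CN(C)S(=O)(=O)c1ccc2c(c1)OCCO2` gives 139000 nM. Compound 3 `C[C@@H]1CN([C@@H](C)CO)C(=O)c2cccc(NC(=O)Nc3cccc4cnccc34)c2O[C@H]1CN(C)S(=O)(=O)c1ccc2c(c1)OCCO2` gives 60500 nM.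

Compound 3 stands second highest of the three, with a 2.3-fold lower number from compound 2 to compound 3 (0.36 log units; beyond the scatter) placing it a little under compound 2 and an 86-fold higher number from compound 1 to compound 3 (1.94 log units; beyond the scatter) placing it far above compound 1. Compound 4 `C[C@@H]1CN([C@@H](C)CO)C(=O)c2cccc(NC(=O)Nc3cccc4cccnc34)c2O[C@H]1CN(C)S(=O)(=O)c1ccc2c(c1)OCCO2` is the next step, with quinolin-8-yl in place of isoquinolin-5-yl on an amide-type nitrogen. Going by the values given here, no measured step matches this change exactly. The measured steps show that where the nitrogen sits within the bicyclic group can shift the result a great deal, as in a 200-fold higher number from compound 1 to compound 2 (2.30 log units; beyond the scatter) and an 86-fold higher number from compound 1 to compound 3 (1.94 log units; beyond the scatter), or only modestly, as in a 2.3-fold lower number from compound 2 to compound 3 (0.36 log units; beyond the scatter). A large change in either direction is therefore possible, and the low value of compound 1 warns that a bicyclic group of this kind can sit far below compound 3. Compound 4 is expected to fall below compound 3, with an expected step of a 10-fold lower number from compound 3 to compound 4 (1.00 log units; beyond the scatter). The estimate for compound 4 is 6000 nM, within a range from 600 nM to 60000 nM.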

Compound 4, solubility: 1800 nM
Beside the measured number, compound 4's estimate is 3.3-fold (0.52 log units) above it, and the stated range covers the measured number.
By their numbers in this assay, from the lowest: compound 1; then compound 4; then compound 3; then compound 2.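

In this assay, the swap to quinolin-8-yl keeps the atoms and the counted features of the group the same, yet it gives a 34-fold lower number from compound 3 to compound 4 (1.53 log units; beyond the scatter). Changing only the attachment point on the quinoline gives a 77-fold lower number from compound 2 to compound 4 (1.89 log units; beyond the scatter), so this position on the amide-type nitrogen can respond sharply to how the same atoms are joined. The four compounds now form a low pair and a high pair, with a 2.6-fold higher number from compound 1 to compound 4 (0.41 log units; beyond the scatter) separating the low pair by far less than either step above, and nothing measured here explains this split.

The compounds shown leave open how naphthalen-1-yl, with carbon alone in both rings, would compare. They also leave open what an added amine on the quinolin-8-yl group would do to the number.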